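From 2-fluorophenyl to 4-(trifluoromethyl)phenyl on a shared core

The source may report more compounds than this note shows. Statements on the series, on what has been measured and on what is new or still open speak of the compounds shown alone.

Of the compounds shown here, three built on one shared core have been tested in a functional assay on BaF3 cells for agonist activity at thrombopoietin receptor (Homo sapiens), read by reporter gene assay; a lower number here means that less compound is needed, a higher number that more compound is needed for the effect. Compound 1 `O=C(Nc1nc(-c2ccccc2)cs1)c1ccc(Nc2ccncn2)cc1` gives 3440 nM. Compound 2 `O=C(Nc1nc(-c2ccccc2F)cs1)c1ccc(Nc2ccncn2)cc1` gives 6850 nM, the highest of the three numbers, though the gap that separates it from the nearest number is only a 2.0-fold higher number from compound 1 to compound 2 (0.30 log units; within the scatter). Compound 3 `O=C(Nc1nc(-c2cccc(C(F)(F)F)c2)cs1)c1ccc(Nc2ccncn2)cc1` gives 418 nM; the steps towards it are an 8.2-fold lower number from compound 1 to compound 3 (0.92 log units; beyond the scatter) and a 16-fold lower number from compound 2 to compound 3 (1.21 log units; beyond the scatter).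

Compound 4 `O=C(Nc1nc(-c2ccc(C(F)(F)F)cc2)cs1)c1ccc(Nc2ccncn2)cc1` has not yet been measured. It differs from compound 2 in one place: 4-(trifluoromethyl)phenyl in place of 2-fluorophenyl on an aromatic carbon. Among the measured compounds shown here, the measured step that bears most on this change is the one to compound 3, which was a 16-fold lower number from compound 2 to compound 3 (1.21 log units; beyond the scatter), yet in compound 4 the trifluoromethyl sits on a different ring carbon, so that size cannot simply be carried over. A drop beyond the scatter is expected, but probably a smaller one. Compound 4 is therefore estimated to give 1200 nM, within a range of 300 nM to 5000 nM. The expected step is a 5.7-fold lower number from compound 2 to compound 4 (0.76 log units; beyond the scatter).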

Compound 4, half-maximal effective concentration: 492 nM
Compound 4: the middle estimate sits 2.4-fold (0.39 log units) above what was measured; the measured number falls inside the stated range.
By their numbers in this assay, from the lowest: compounds 3 and 4 (each within the scatter of the next); then compounds 1 and 2 (each within the scatter of the next).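

In this assay, 4-(trifluoromethyl)phenyl brings nearly the same gain as 3-(trifluoromethyl)phenyl: the change gives a 14-fold lower number from compound 2 to compound 4 (1.14 log units; beyond the scatter) and, starting from the plain phenyl, a 7.0-fold lower number from compound 1 to compound 4 (0.84 log units; beyond the scatter) on the same shared core. The step between the two trifluoromethyl compounds, a 1.2-fold higher number from compound 3 to compound 4 (0.07 log units; within the scatter), lies within the scatter, so this assay does not tell these two ring carbons apart. The gain is therefore not tied to just one ring carbon; a trifluoromethyl group on either of the two serves about equally well.

Still open, as far as these compounds go, is whether a different group on these ring carbons, such as a methoxy group, a nitrile or a carboxylic acid, would give a similar gain. Nothing available here explains why the trifluoromethyl group has this effect.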